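A few compounds are considered here, and "the series" means these few. Any claim that something is new, unique, unknown or untested is made for them only; others in the source may bear on it.

Of the compounds shown here, three have been measured in an assay on HEK293 cells for positive allosteric modulation of metabotropic glutamate receptor 2 (Rattus norvegicus), read by thallium flux, with a stated time of 2.5 min; a higher number here means a larger maximal response, a lower number a smaller maximal response. Compound 1 `Cc1c(OCCCCOc2ccccc2C(=O)O)ccc(C(=O)CC2CCCC2)c1C` gives 67.1%, the lowest of the three numbers. Compound 2 `Cc1c(OCCCCOc2ccccc2C(=O)O)ccc(C(=O)CC2CCCC2)c1O` gives 98.8%, and compound 3 `Cc1c(OCCCCOc2ccc(C(=O)O)cc2F)ccc(C(=O)CC(C)C)c1O` gives 85%. Going by the values given here, the only single-point step measured so far, a number 31.7 percentage points higher from compound 1 to compound 2 (beyond the scatter), concerns hydroxy in place of methyl on an aromatic carbon. The new compound 4 `Cc1c(OCCCCOc2cccc(C(=O)O)c2)ccc(C(=O)CC2CCCC2)c1C` differs from compound 1 in another way: 3-carboxyphenyl in place of 2-carboxyphenyl on an oxygen on a saturated carbon. Among the compounds with values here, no measured step covers the swap of 2-carboxyphenyl for 3-carboxyphenyl, so the data give no direction for this change. With nothing to lean on, the expected step is a number 7.1 percentage points lower from compound 1 to compound 4 (within the scatter), small and uncertain. Compound 4 is therefore estimated at 60%, between 35% and 90%.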

Compound 4, largest response reached (reported as percent of maximum), in percent of the reference or control that the assay uses: 22.4%
Estimate against measurement, compound 4: 37.6 percentage points above; the measured number lies below the stated range.
By their numbers in this assay, from the lowest: compound 4; then compound 1; then compound 3; then compound 2.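

Replacing 2-carboxyphenyl with 3-carboxyphenyl keeps the same atoms and only joins them differently, yet it gives a number 44.7 percentage points lower from compound 1 to compound 4 (beyond the scatter) in this assay on the core of compound 1. For this pair, the maximal response therefore depends strongly on how the carboxyphenyl group is attached, not only on which atoms are present. No supporting measurement explains the drop.

On these data alone, it remains open whether hydroxy in place of methyl would raise the response of compound 4 as well. Also open, as far as these compounds go, is whether a tetrazole in place of the carboxylic acid would restore the response.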